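This account rests on a few compounds, and the source may have more. Where it says the series, first, only, none or still open, it means among the compounds named here.

Measured compounds:
- Compound 1 `C[C@@H]1C[C@H]1C(=O)N1CC2CNCC2C1`: 110%
- Compound 2 `C[C@H]1C[C@@H]1C(=O)N1CC2CNCC2C1`: 26%
- Compound 3 `CCC(=O)N1CC2CNCC2C1`: 130%

In an assay on CHO cells for agonist activity at Neuronal acetylcholine receptor; alpha3/beta4 (Homo sapiens), read by FLIPR and calcium flux (a higher number here means a larger maximal response, a lower number a smaller maximal response), compound 1 gives 110%, the second highest of the three numbers. Compound 3 sits above it by a number 20 percentage points higher from compound 1 to compound 3 (beyond the scatter), while compound 2 sits far below it by a number 84 percentage points lower from compound 1 to compound 2 (beyond the scatter); compound 1 and compound 2 have the same atoms and bonds and differ only in how two stereocentres are drawn (the fact that one of compounds 1 and 2 is drawn with a defined configuration and the other without, at the place where they differ).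

Compound 4 `COC(=O)N1CC2CNCC2C1` has not yet been measured. It differs from compound 1 in one place: methoxy in place of 2-methylcyclopropyl on a carbonyl carbon. Among the compounds with values here, two measured steps bear on this, both swapping the 2-methylcyclopropyl on the carbonyl carbon for a smaller group, ethyl: a number 20 percentage points higher from compound 1 to compound 3 (beyond the scatter) and a number 104 percentage points higher from compound 2 to compound 3 (beyond the scatter). Starting from compound 1, the swap to ethyl gave only a modest rise, so a swap to methoxy, another small group on the same carbonyl carbon, is expected to move the maximal response in this assay by a step of similar or smaller size, upward or within the scatter, as a number 5 percentage points higher from compound 1 to compound 4 (within the scatter).

For compound 4 the estimated result in this assay is 115%, expected to fall between 85% and 145%.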

Compound 4, largest response reached (Emax), in percent of the reference or control that the assay uses: 85%
Compound 4: the middle estimate sits 30 percentage points above what was measured, within the range that was stated.
By their numbers in this assay, from the lowest: compound 2; then compound 4; then compound 1; then compound 3.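

The group on the carbonyl carbon matters even when no ring is involved: in this assay, ethyl and methoxy both lack a ring, yet the swap from one to the other gives a number 45 percentage points lower from compound 3 to compound 4 (beyond the scatter). Removing the 2-methylcyclopropyl therefore does not by itself raise the maximal response, as methoxy in its place gives a number 25 percentage points lower from compound 1 to compound 4 (beyond the scatter), the opposite direction to the rise seen with ethyl, while the same swap starting from the other stereo form gives a number 59 percentage points higher from compound 2 to compound 4 (beyond the scatter). The outcome of a change at this position thus depends both on which group enters and on which stereo form of the 2-methylcyclopropyl leaves, so one measured swap here does not fix the size or even the direction of another.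

Nothing in the data shown explains why methoxy gives a smaller maximal response than ethyl. As far as these compounds go, it also remains open where an amine-linked group such as dimethylamino or a longer chain such as propyl on the same carbonyl carbon would fall relative to compound 3 and compound 4.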